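From compound 1 to compound 3: one added hydroxy

This account rests on a few compounds, and the source may have more. Where it says the series, first, only, none or still open, it means among the compounds named here.

Among the measured compounds shown here, in an ADME assay on MDCK cells (Canis lupus familiaris) for cytotoxicity, read by MTT assay, with a stated time of 72 h (on this read-out higher numbers stand for weaker inhibition and lower numbers for stronger inhibition), compound 1 `Cc1cc(/C=C/c2ccc(O)cc2)[nH]n1` gives 80000 nM, the higher of the two numbers measured so far. Compound 2 `COc1ccc(/C=C/c2cc(C)n[nH]2)cc1` gives 16500 nM. For the measured compounds named here, the single measured step, a 4.8-fold lower number from compound 1 to compound 2 (0.69 log units; beyond the scatter), places methyl in place of hydrogen on an oxygen on an aromatic ring. Compound 3 `Cc1cc(/C=C/c2ccc(O)c(O)c2)[nH]n1` carries a different change on that same ring: hydroxy in place of hydrogen on an aromatic carbon, ortho to a hydroxy group. Going by the values given here, no measured step covers this change directly, so the guide is indirect. Going by the modest step of a 4.8-fold lower number from compound 1 to compound 2 (0.69 log units; beyond the scatter), a change of similar or smaller size toward a lower number is expected in this assay, with wide uncertainty. The estimated step is a 2.7-fold lower number from compound 1 to compound 3 (0.43 log units; beyond the scatter). For compound 3 the expected value is 30000 nM, with an estimated range of 9000 nM to 90000 nM.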

Compound 3, half-maximal inhibitory concentration: > 100000 nM
Compound 3 was reported as a limit (the forecaster's own chance of this, stated with the estimate: 10%); at least 3.3-fold (0.52 log units) between middle value and limit.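

Compound 3 reads > 100000 nM in this assay, a limit of the assay and not a number: the limit of > 100000 nM in this assay, at which 1 of the 3 values shown sits.

The step is an at least 1.2-fold higher number from compound 1 to compound 3 (0.09 log units; that floor lies within the scatter). Among the compounds shown here, a hydroxy on this aromatic carbon, ortho to a hydroxy group, therefore brings no lower number, unlike the one earlier change on this ring, which acted on the oxygen of the hydroxy group. Whether the number truly rises, and by how much, cannot be read: only the floor of the step is known, and that floor does not clear the scatter.

From the compounds shown here alone, it remains open whether this outcome belongs to the position or to the hydroxy group itself. An amine or a fluorine on the same aromatic carbon would separate the two, and the limit leaves the size of any change unresolved.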